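Adding a Methyl to the Phenyl of Compound 1

This account rests on a few compounds, and the source may have more. Where it says the series, first, only, none or still open, it means among the compounds named here.

Compound 1, `Clc1ccc(C2CC(c3ccc(N4CCCCC4)cc3)=NN2c2nc(-c3ccccc3)cs2)cc1`, gives 64200 nM in a functional assay on A549 cells (Homo sapiens) for antiproliferative activity, read by MTT assay, with a stated time of 72 h; a lower number here means a stronger inhibitor, a higher number a weaker inhibitor.
Compound 3, `Fc1ccc(-c2csc(N3N=C(c4ccc(N5CCCCC5)cc4)CC3c3ccc(Cl)cc3)n2)cc1`, gives 70200 nM.
Compound 2, `O=[N+]([O-])c1ccc(-c2csc(N3N=C(c4ccc(N5CCCCC5)cc4)CC3c3ccc(Cl)cc3)n2)cc1`, gives only a limit of the assay, > 100000 nM.

Compound 1 stands with compound 3, the two within the scatter of each other: a 1.1-fold higher number from compound 1 to compound 3 (0.04 log units; within the scatter). Compound 4, `Cc1ccc(-c2csc(N3N=C(c4ccc(N5CCCCC5)cc4)CC3c3ccc(Cl)cc3)n2)cc1`, differs from compound 1 by methyl in place of hydrogen on an aromatic carbon. Two measured steps also place a new group on this same aromatic carbon, a 1.1-fold higher number from compound 1 to compound 3 (0.04 log units; within the scatter) and an at least 1.5-fold higher number from compound 1 to compound 2 (0.19 log units; that floor lies within the scatter), the second resting on (the limit of > 100000 nM in this assay, at which 1 of the 3 values shown sits). Neither moves the number beyond the scatter, so for methyl no step beyond the scatter is expected in this assay either. The expected step is a 1.1-fold higher number from compound 1 to compound 4 (0.04 log units; within the scatter). Compound 4 is therefore estimated at 70000 nM, with a range from 35000 nM to 140000 nM.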

Compound 4, half-maximal inhibitory concentration: > 100000 nM
Compound 4 was reported as a limit; the forecaster's own chance of this, stated with the estimate: 25%; middle value at least 1.4-fold (0.15 log units) away from the limit.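

In this assay compound 4 gives only a limit, not a number, so methyl joins nitro at that limit, while fluoro still gives a measured value. The readable steps, an at least 1.5-fold higher number from compound 1 to compound 4 (0.19 log units; that floor lies within the scatter) and an at least 1.4-fold higher number from compound 3 to compound 4 (0.15 log units; that floor lies within the scatter), have floors within the scatter, so they show no firm loss, though a larger one stays possible. The step between compound 2 and compound 4 cannot be read, because both compounds rest on a limit: the limit of > 100000 nM in this assay, at which 2 of the 4 values shown sit.

Still open, from the compounds shown here alone, is how far above the limit compound 2 and compound 4 lie. Also open, going by these compounds, is whether an amine or a carboxylic acid on this carbon would lower the number beyond the scatter.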